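Moving a trifluoromethyl group: compound 2 to compound 3

The compounds below may be only part of what the source reports. "The series", "measured", "known", "first", "only" and "open" are said of these compounds alone.

Measured so far in an ADME assay on HEK-293T cells (Homo sapiens) for cytotoxicity, read by MTT assay, with a stated time of 3 days; a higher number here means that more compound is tolerated, a lower number that less compound is tolerated:
Compound 1 (`CC(=O)Oc1ccccc1CN(C(=O)COC(=O)c1ccc([N+](=O)[O-])o1)C(C)(C)C`) gives > 100000 nM (a limit of the assay, not a number)
Compound 2 (`CC(C)(C)N(Cc1ccc(C(F)(F)F)cc1)C(=O)COC(=O)c1ccc([N+](=O)[O-])o1`) gives 36000 nM

Among the measured compounds shown here, compound 2 holds the only actual number among the measured compounds, since the other value is a limit. Compound 3 (`CC(C)(C)N(Cc1ccccc1C(F)(F)F)C(=O)COC(=O)c1ccc([N+](=O)[O-])o1`) has not yet been measured. It has the same atoms as compound 2, joined differently: 2-(trifluoromethyl)phenyl in place of 4-(trifluoromethyl)phenyl on a saturated chain carbon bound to an amide-type nitrogen. In words, 2-(trifluoromethyl)phenyl stands in place of 4-(trifluoromethyl)phenyl on a saturated chain carbon bound to an amide-type nitrogen.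

For the measured compounds named here, only one measured step bears on this change, an at least 2.7-fold lower number from compound 1 to compound 2 (0.44 log units; beyond the scatter), and it lies beyond the scatter. That step exchanges one group for a different one, so it does not test a move of the trifluoromethyl group. Going by the values given here, the data hold no direct precedent for such a move. The step expected here is therefore small, with no change beyond the scatter and at most a slight tilt towards more tolerance: a 1.2-fold higher number from compound 2 to compound 3 (0.07 log units; within the scatter). For compound 3 the estimated value in this assay is 42000 nM, with an expected range from 17000 nM to 100000 nM.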

Compound 3, half-maximal cytotoxic concentration: 65000 nM
Beside the measured number, compound 3's estimate is 1.5-fold (0.19 log units) below it; low and high end bracket the measured number.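

In this assay, among the compounds shown here, moving the trifluoromethyl group gives the first direct look at where this group sits, and the result is a 1.8-fold higher number from compound 2 to compound 3 (0.26 log units; within the scatter), so the data set no order between 2-(trifluoromethyl)phenyl and 4-(trifluoromethyl)phenyl on a saturated chain carbon bound to an amide-type nitrogen. The exchange of acetoxy for trifluoromethyl on an aromatic carbon, now seen with the group in its new place, reads as an at least 1.5-fold lower number from compound 1 to compound 3 (0.18 log units; that floor lies within the scatter), which means that this pair, unlike the earlier step with 4-(trifluoromethyl)phenyl, does not establish a change beyond the scatter. Compound 1 carries a limit of the assay and not a number, so the true size of this step stays unknown: the limit of > 100000 nM in this assay, at which 1 of the 3 values shown sits.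

The compounds shown leave open whether a nitrile, an amine or a carboxylic acid in place of trifluoromethyl on an aromatic carbon would shift the number beyond the scatter. They also do not tell whether a longer chain in place of the saturated chain carbon bound to the amide-type nitrogen would change how much compound is tolerated.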